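Series notes: triazole substituent change, compound 3 to compound 4

The source may report more compounds than this note shows. Statements on the series, on what has been measured and on what is new or still open speak of the compounds shown alone.

The shared core carries a triazole whose nitrogen substituent varies. Compound 1 `CCCn1cc(COc2cc(O)c3c(c2)O[C@H](c2ccc(OC)c(O)c2)C/C3=N\O)nn1` gives 2340 nM in a functional assay on RAW264.7 cells (Mus musculus) for inhibition, read by Griess assay, with stated times of 2 h and 24 h; a lower number here means a stronger inhibitor, a higher number a weaker inhibitor. Compound 2 `COc1ccc([C@@H]2C/C(=N\O)c3c(O)cc(OCc4cn(C5CCCC5)nn4)cc3O2)cc1O` gives 6880 nM in this assay, and compound 3 `COc1ccc([C@@H]2C/C(=N\O)c3c(O)cc(OCc4cn(CC5CC5)nn4)cc3O2)cc1O` gives 6320 nM. Compound 3 stands second highest of the three numbers: it sits close to compound 2, with a 1.1-fold lower number from compound 2 to compound 3 (0.04 log units; within the scatter), and apart from compound 1, with a 2.7-fold higher number from compound 1 to compound 3 (0.43 log units; beyond the scatter).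

Compound 4 `COc1ccc([C@@H]2C/C(=N\O)c3c(O)cc(OCc4cn(Cc5ccccc5Cl)nn4)cc3O2)cc1O` is unmeasured; the change is 2-chlorophenyl in place of cyclopropyl on a saturated chain carbon bound to an aromatic nitrogen. Within the data shown here, no measured step introduces an aromatic ring at this place. Among the measured compounds shown here, the steps that bear on it only loosely are a 2.9-fold higher number from compound 1 to compound 2 (0.47 log units; beyond the scatter) and a 2.7-fold higher number from compound 1 to compound 3 (0.43 log units; beyond the scatter), both modest moves toward higher numbers as the group grows from a small chain, while a 1.1-fold lower number from compound 2 to compound 3 (0.04 log units; within the scatter) shows the two larger groups close together. On that basis no step beyond the scatter is expected in this assay, with the wider uncertainty toward either side. Compound 4 is expected at 5500 nM, with a range from 1500 nM to 20000 nM. That estimate means a 1.1-fold lower number from compound 3 to compound 4 (0.06 log units; within the scatter).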

Compound 4, half-maximal inhibitory concentration: 13400 nM
Estimate against measurement, compound 4: 2.4-fold (0.39 log units) below; measured number inside the range.
By their numbers in this assay, from the lowest: compound 1; then compounds 3, 2 and 4 (each within the scatter of the next, the first and the last beyond it).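

In this assay, the first aromatic ring at this place, 2-chlorobenzyl in place of cyclopropylmethyl, gives a 2.1-fold higher number from compound 3 to compound 4 (0.33 log units; beyond the scatter) and so does not bring the number back toward that of compound 1. Against the cyclopentyl group the same change stays within the scatter, at a 1.9-fold higher number from compound 2 to compound 4 (0.29 log units; within the scatter), while against the propyl group the gap widens to a 5.7-fold higher number from compound 1 to compound 4 (0.76 log units; beyond the scatter) and compound 1 keeps the lowest number of the four. No measured evidence accounts for this result.

On these data alone, whether the ring or the chlorine carries the step remains open, and a plain benzyl group would separate the two. Also open, as far as these compounds go, is whether a butyl chain or a chain ending in an amine at this place would stay near compound 1 or move away from it.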